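A few compounds are considered here, and "the series" means these few. Any claim that something is new, unique, unknown or untested is made for them only; others in the source may bear on it.

Compound 1 `Cc1cc(NCc2cccnc2)n2nc(C)c(-c3ccccc3)c2n1` has been measured in a physicochemical assay for solubility, read by HPLC, using the shake flask method, measured as kinetic solubility, with a stated time of 2 h, at pH 7.4 (a lower number here means a less soluble compound, a higher number a more soluble compound), where compound 1 gives 110000 nM. For the measured compounds named here, that is the only actual number among the three compounds examined so far. Compound 2 `Cc1cc(NCc2ccccn2)n2ncc(-c3ccc(C(F)(F)F)cc3)c2n1` reaches only a limit of the assay, giving < 5000 nM. Compound 3 `Cc1cc(NCc2ccccn2)n2ncc(-c3ccccc3C)c2n1` likewise stops at a limit, giving < 5000 nM. Going by the values given here, compound 1 therefore stands alone as the one compound with a quantified solubility, while the other two sit at the limit of < 5000 nM in this assay, at which 2 of the 3 values shown sit.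

Compound 4 `Cc1cc(NCc2ccc(F)cn2)n2nc(C)c(-c3ccccc3)c2n1` has not yet been measured. It differs from compound 1 in a single place: 5-fluoropyridin-2-yl in place of pyridin-3-yl on a saturated chain carbon bound to a nitrogen on an aromatic ring. The pyridin-3-yl group gives way to a 5-fluoropyridin-2-yl group on the saturated chain carbon bound to a nitrogen on an aromatic ring, and the shared core is otherwise untouched. Among the compounds with values here, no pair of measured compounds differs in exactly this way, so the size of this step cannot be read from the measurements in hand. A moderate decrease in solubility is expected, somewhat beyond the usual scatter but well short of the assay limit, although a result indistinguishable from compound 1 would not be a surprise. The expected step from compound 1 to compound 4 is a 2.4-fold lower number from compound 1 to compound 4 (0.39 log units; beyond the scatter). Compound 4 is accordingly estimated at 45000 nM, with a likely range from 12000 nM to 130000 nM.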

Compound 4, solubility: < 5000 nM
Compound 4 ended at the assay's limit; the forecaster's own chance of this, stated with the estimate: 15%; at least 9.0-fold (0.95 log units) between middle value and limit.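

In this assay, replacing pyridin-3-yl with 5-fluoropyridin-2-yl on a saturated chain carbon bound to a nitrogen on an aromatic ring gives an at least 22-fold lower number from compound 1 to compound 4 (1.34 log units; beyond the scatter), the only step that can be read among the compounds shown. For the compounds shown here, until now, no measured pair isolated a single change, so this is the first sign that the read-out is sensitive to the group at this place, even with the shared core untouched. Compound 4 gives a limit and not a number, so the step marks only the smallest gap the data allow, and compound 4 joins the compounds that cannot be ranked against one another: the limit of < 5000 nM in this assay, at which 3 of the 4 values shown sit.

The swap moves the ring's point of attachment and adds a fluorine in one step, so the data cannot say how much of the gap belongs to each part, and a plain pyridin-2-yl on the core of compound 1 would be needed to separate them. Also open is how a carboxylic acid or a morpholine ring at this place would read in this assay, since every group shown here is a pyridine ring.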